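Swapping the Ester Group on a Rho Kinase Inhibitor

The compounds below may be only part of what the source reports. "The series", "measured", "known", "first", "only" and "open" are said of these compounds alone.

Measured so far:
Compound 1 `NCc1ccc(C(=O)Nc2ccncc2F)cc1-c1cccc(C(=O)O)c1`: 55 nM in an assay on isolated protein for inhibition of Rho-associated protein kinase 2 (Homo sapiens), read by radiometric assay; a lower number here means a stronger inhibitor, a higher number a weaker inhibitor
Compound 2 `CC(C)OCCOC(=O)c1cccc(-c2cc(C(=O)Nc3ccncc3F)ccc2CN)c1`: 37 nM in this assay

Compound 2 has the lowest of the two numbers in this assay; its nearest neighbour is compound 1, and the step of a 1.5-fold lower number from compound 1 to compound 2 (0.17 log units; within the scatter) lies within the scatter, so the two cannot be ranked against each other.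

Compound 3 `NCc1ccc(C(=O)Nc2ccncc2F)cc1-c1cccc(C(=O)OC2CCCOC2)c1` differs from compound 2 in one place: oxan-3-yl in place of 2-isopropoxyethyl on an oxygen next to a carbonyl group. Among the compounds with values here, the only measured step that touches this position is the one in which 2-isopropoxyethyl took the place of hydrogen on that oxygen, a 1.5-fold lower number from compound 1 to compound 2 (0.17 log units; within the scatter), and it stayed within the scatter. The move to compound 3 exchanges one ester group for another of matching size at the same place, while the rest of the molecule, including the amine and the amide, is unchanged. Within the data shown here, with the single comparable step showing no real movement, the expectation for compound 3 is a step of a 1.1-fold higher number from compound 2 to compound 3 (0.03 log units; within the scatter), that is, nothing beyond the scatter. The estimate for compound 3 in this assay is 40 nM, with a range from 15 nM to 110 nM.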

Compound 3, half-maximal inhibitory concentration: 8.7 nM
Estimate against measurement, compound 3: 4.6-fold (0.66 log units) above, and the stated range ends above it.
By their numbers in this assay, from the lowest: compound 3; then compounds 2 and 1 (each within the scatter of the next).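

In this assay, this position proves able to tell one ester group from another: oxan-3-yl in place of 2-isopropoxyethyl gives a step beyond the scatter (a 4.3-fold lower number from compound 2 to compound 3 (0.63 log units; beyond the scatter)). The two groups have the same counts of heavy atoms, carbon, oxygen and hydrogen-bond acceptors, so the counted difference is that oxan-3-yl closes its atoms into a six-membered non-aromatic ring, whereas 2-isopropoxyethyl has no ring. Oxan-3-yl also separates from hydrogen on the same oxygen (a 6.3-fold lower number from compound 1 to compound 3 (0.80 log units; beyond the scatter)), which 2-isopropoxyethyl did not do, yet no measurement available here accounts for the lower number.

The compounds shown leave open whether the ring itself or the oxygen within it goes with the lower number, a question that cyclohexyl, with carbon in place of that oxygen, and oxan-4-yl, with the oxygen elsewhere in the ring, could help to separate. Going by these compounds, how an amide in place of the ester would compare at this position also remains open.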